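The source may hold more compounds than are shown below. What is called first, only, known or untested is meant among the compounds shown, and "the series" means these compounds.

Compound 3 `Cc1cc(NCc2ccccn2)n2ncc(C3=CCC(F)(F)CC3)c2n1` carries a 4,4-difluorocyclohex-1-en-1-yl group on the shared core. In a physicochemical assay for solubility, read by HPLC, using the shake flask method, measured as kinetic solubility, with a stated time of 2 h, at pH 7.4 (on this read-out lower numbers stand for lower solubility and higher numbers for higher solubility), compound 3 gives 5000 nM, the lower of the two numbers recorded here. Compound 2 `Cc1cc(NCc2ccccn2)n2ncc(-c3ccncc3)c2n1`, which bears a pyridin-4-yl group at the same place, gives 161000 nM in this assay. Compound 1 `Cc1cc(NCc2ccccn2)n2ncc(-c3ccccc3C)c2n1` carries a 2-methylphenyl group there. In this assay compound 1 reports only a limit, < 5000 nM, described by the limit of < 5000 nM in this assay, at which 1 of the 3 values shown sits. The measured steps that bear on the next change are a 32-fold lower number from compound 2 to compound 3 (1.51 log units; beyond the scatter) and a number no lower from compound 1 to compound 3 (the limit leaves the size open). Compound 4 `Cc1cc(NCc2ccccn2)n2ncc(-c3ccc(F)cc3C)c2n1` differs from compound 3 in that (4-fluoro-2-methylphenyl in place of 4,4-difluorocyclohex-1-en-1-yl on an aromatic carbon). The entering group is a close relative of the 2-methylphenyl of compound 1, whose result was a limit. Compound 1 with its limit value < 5000 nM is therefore the nearest guide. The step from compound 3 to compound 4 is expected to be a 1.7-fold lower number from compound 3 to compound 4 (0.22 log units; within the scatter), a modest fall with a fair chance of another limit. Compound 4 is estimated at 3000 nM, within 1000 nM to 8000 nM.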

Compound 4, solubility: 42300 nM
The estimate for compound 4 lay 14-fold (1.15 log units) below the measured number; the whole stated range lies below it.
By their numbers in this assay, from the lowest: compound 3; then compound 4; then compound 2.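

In this assay, a carbon-only aromatic ring at this position need not sit at the bottom of the series: replacing the 4,4-difluorocyclohex-1-en-1-yl group gives an 8.5-fold higher number from compound 3 to compound 4 (0.93 log units; beyond the scatter), although the pyridin-4-yl group keeps the lead, with a 3.8-fold lower number from compound 2 to compound 4 (0.58 log units; beyond the scatter). A single fluoro added to the 2-methylphenyl ring gives an at least 8.4-fold higher number from compound 1 to compound 4 (0.92 log units; beyond the scatter), a sizeable step for so small a change. Compound 1 reports a limit and not a number, which leaves the full size of that step unknown: the limit of < 5000 nM in this assay, at which 1 of the 4 values shown sits.

Still open, going by these compounds, is how a phenyl ring carrying an amine or a carboxylic acid would read at this position. Also open, on these data alone, is whether the fluoro step would hold on any ring other than 2-methylphenyl.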